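Dimethoxyphenyl in place of 4-chlorophenyl: compound 1 to compound 4

The source may report more compounds than this note shows. Statements on the series, on what has been measured and on what is new or still open speak of the compounds shown alone.

In a physicochemical assay, read by spectrophotometry, with a stated time of 30 min (a higher number here means a weaker inhibitor, a lower number a stronger inhibitor), compound 1 `O=C(CC(c1ccc(Cl)cc1)c1c[nH]c2ccccc12)c1c(O)c2ccccc2oc1=O` gives 46.4 ug/mL and sits within the scatter of compound 2 `O=C(CC(c1ccc(F)cc1)c1c[nH]c2ccccc12)c1c(O)c2ccccc2oc1=O` at 47.4 ug/mL as a 1.0-fold higher number from compound 1 to compound 2 (0.01 log units; within the scatter) shows. Both stand above compound 3 `COc1ccc(C(CC(=O)c2c(O)c3ccccc3oc2=O)c2c[nH]c3ccccc23)c(OC)c1` at 13.2 ug/mL on this scale. Compound 4 `COc1ccc(OC)c(C(CC(=O)c2c(O)c3ccccc3oc2=O)c2c[nH]c3ccccc23)c1` is still unmeasured. The change (2,5-dimethoxyphenyl in place of 4-chlorophenyl on a saturated chain carbon bound to an aromatic carbon and a saturated chain carbon) puts 2,5-dimethoxyphenyl in place of 4-chlorophenyl on a saturated chain carbon bound to an aromatic carbon and a saturated chain carbon. The nearest evidence is the 2,4-dimethoxyphenyl change in compound 3 with a 3.5-fold lower number from compound 1 to compound 3 (0.55 log units; beyond the scatter) and a 3.6-fold lower number from compound 2 to compound 3 (0.56 log units; beyond the scatter) as modest steps beyond the scatter. Going by the values given here, no compound measured so far carries 2,5-dimethoxyphenyl. A step of similar size and direction is therefore expected in this assay with a 2.7-fold lower number from compound 1 to compound 4 (0.44 log units; beyond the scatter) as the estimate. For compound 4 the estimated value is 17 ug/mL with an expected range from 8 ug/mL to 36 ug/mL at this stage.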

Compound 4, half-maximal inhibitory concentration: 19 ug/mL
Beside the measured number, compound 4's estimate is 1.1-fold (0.05 log units) below it; measured number inside the range.
By their numbers in this assay, from the lowest: compounds 3 and 4 (each within the scatter of the next); then compounds 1 and 2 (each within the scatter of the next).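

In this assay, the drop seen with compound 3 does not belong to the 2,4-dimethoxyphenyl group alone: 2,5-dimethoxyphenyl on the same saturated chain carbon gives a 2.4-fold lower number from compound 1 to compound 4 (0.39 log units; beyond the scatter) and a 2.5-fold lower number from compound 2 to compound 4 (0.40 log units; beyond the scatter) in the same direction. Moving between the two dimethoxyphenyl groups gives a 1.4-fold higher number from compound 3 to compound 4 (0.16 log units; within the scatter) and so separates them by nothing that can be read. No evidence bears on the reason for these steps.

From the compounds shown here alone, whether a phenyl carrying a single methoxy group keeps the step remains open. So does the outcome with a hydroxy group or a dimethylamino group in place of methoxy.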